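The source may report more compounds than this note shows. Statements on the series, on what has been measured and on what is new or still open speak of the compounds shown alone.

Compound 1 `Cc1nc(NC(C)C)nc(N[C@@H]2C[C@H](CO)[C@@H](O)[C@H]2O)c1-c1nc2ccccc2s1` gives 13000 nM in an ADME assay on cells (Homo sapiens) for cytotoxicity, read by polymerase chain reaction, with a stated time of 3 days; on this read-out higher numbers stand for lower toxicity in this test and lower numbers for higher toxicity in this test.
Compound 2 `Cc1nc(NCC2CC2)nc(N[C@@H]2C[C@H](CO)[C@@H](O)[C@H]2O)c1-c1nc2ccccc2s1` gives 8000 nM in this assay.
Compound 3 `Cc1nc(NCCNS(C)(=O)=O)nc(N[C@@H]2C[C@H](CO)[C@@H](O)[C@H]2O)c1-c1nc2ccccc2s1` gives only a limit in this assay, > 25000 nM.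

Compound 3 therefore stands at the edge of what this assay can report; only a bound is known for it (the limit of > 25000 nM in this assay, at which 1 of the 3 values shown sits). Compound 4 `Cc1nc(NCc2cccnc2)nc(N[C@@H]2C[C@H](CO)[C@@H](O)[C@H]2O)c1-c1nc2ccccc2s1` differs from compound 3 by pyridin-3-yl in place of (methanesulfonamido)methyl on a saturated chain carbon bound to a nitrogen on an aromatic ring. Among the compounds with values here, the steps that bear on this change are an at least 1.9-fold higher number from compound 1 to compound 3 (0.28 log units; that floor lies within the scatter) and an at least 3.1-fold higher number from compound 2 to compound 3 (0.49 log units; beyond the scatter), both moving toward the limit when (methanesulfonamido)methyl enters. Undoing that entry is expected to move the number back toward those of compound 1 and compound 2, so a downward step is expected, an at least 2.0-fold lower number from compound 3 to compound 4 (0.31 log units; beyond the scatter), though the bound on compound 3 leaves its true size open. Compound 4 is estimated at 12000 nM, within 5000 nM to 25000 nM.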

Compound 4, half-maximal cytotoxic concentration: 5000 nM
Compound 4: the middle estimate sits 2.4-fold (0.38 log units) above what was measured; the range from low to high includes it.
By their numbers in this assay, from the lowest: compounds 4, 2 and 1 (each within the scatter of the next, the first and the last beyond it). At a limit, above all of these: compound 3.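

With pyridin-3-yl at this place, the series shows an at least 5.0-fold lower number from compound 3 to compound 4 (0.69 log units; beyond the scatter), so this aromatic ring does not keep the number at the limit. Set against the smaller groups, it gives a 1.6-fold lower number from compound 2 to compound 4 (0.20 log units; within the scatter) and a 2.6-fold lower number from compound 1 to compound 4 (0.41 log units; beyond the scatter), so only the isopropyl comparison clearly separates the pair. The first of these steps is only a floor, since compound 3 gives a limit of the assay, not a number: the limit of > 25000 nM in this assay, at which 1 of the 4 values shown sits.

Going by these compounds, how far compound 3 truly lies beyond that limit stays open. So does whether an acetamide or a carboxylic acid on this chain would also reach it.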